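This account rests on a few compounds, and the source may have more. Where it says the series, first, only, none or still open, it means among the compounds named here.

Series notes. Compound 1 `COc1ccccc1-c1cc(C2CCN(C)C2)ccc1Cl` and compound 2 `CCCCNCc1ccc(Cl)c(-c2ccccc2OC)c1` share the same core. In a functional assay on HEK293 cells for agonist activity at 5-hydroxytryptamine receptor 7 (Homo sapiens), read by cAMP accumulation, with a stated time of 30 min (on this read-out lower numbers stand for smaller maximal responses and higher numbers for larger maximal responses), compound 1 gives 9.8%. In this assay compound 2 is recorded as "not active" (no number reported), so compound 2 stands without any number in this read-out. Compound 3 `CCCNCc1ccc(Cl)c(-c2ccccc2OC)c1` differs from compound 2 by hydrogen in place of methyl on a saturated chain carbon, three bonds along the chain from an amine nitrogen. Within the data shown here, no measured pair shows this step, so in this assay no shift beyond the usual scatter is expected, in either direction. Because compound 2 gives "not active" (no number reported), compound 3 is expected in this assay at about 8%, within 0% to 25%.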

Compound 3, largest response reached (Emax), in percent of the reference or control that the assay uses: 68%
Beside the measured number, compound 3's estimate is 60 percentage points below it; measured number above the stated range.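

In this assay the chain on the amine proves decisive at this position: with butyl to propyl, compound 2 is recorded as "not active" (no number reported) and compound 3 gives 68% even though this step cannot be read as a number. Placing (propylamino)methyl in place of 1-methylpyrrolidin-3-yl on an aromatic carbon gives a number 58.2 percentage points higher from compound 1 to compound 3 (beyond the scatter) and so shows that the core can carry a large response in this assay. No supporting data bear on the origin of either difference.

From the compounds shown here alone, how an ethyl or isopropyl group on the amine would behave remains open. So does whether a pyrrolidine carrying a propyl group on its nitrogen would keep the response of compound 3.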